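A few compounds are considered here, and "the series" means these few. Any claim that something is new, unique, unknown or untested is made for them only; others in the source may bear on it.

Compound 1 `COc1cc(C)cc(-c2c(-c3ccnc(-c4ccc(C(C)=O)cc4)c3)cnn2CC#N)c1` was tested in a functional assay on BT-549 cells (Homo sapiens) for inhibition, read by sulforhodamine B assay, with a stated time of 48 h; a higher number here means a weaker inhibitor of growth, a lower number a stronger inhibitor of growth. In this assay compound 1 gives > 100000 nM, which is a limit of the assay and not a number. Two related compounds give numbers. Compound 2 `COc1cc(C)cc(-c2nn(CC#N)cc2-c2ccc(-c3cccc(C(C)=O)c3)nc2)c1`, which carries the acetyl group at a different point of its phenyl ring, gives 15100 nM in this assay. Compound 3 `Cc1cc(O)cc(-c2nn(CC#N)cc2-c2ccnc(-c3ccc(N(C)C)cc3)c2)c1`, which carries a dimethylamino group in place of the acetyl and a hydroxyl in place of the methoxy, gives 12100 nM in this assay. Those two values lie within the usual scatter of each other, so no order between compound 2 and compound 3 can be read. Compound 1 alone sits at the limit of > 100000 nM in this assay, at which 1 of the 3 values shown sits.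

Compound 4 `COc1cc(C)cc(-c2c(-c3ccnc(-c4ccc(N(C)C)cc4)c3)cnn2CC#N)c1` differs from compound 1 in one place: dimethylamino in place of acetyl on an aromatic carbon. Going by the values given here, no measured pair shows exactly this change. The nearest guide is compound 3, which also carries the dimethylamino group and gives 12100 nM in this assay. On that basis the step from compound 1 to compound 4 is expected to move the value down from the limit into measurable territory, by an at least 5.0-fold lower number from compound 1 to compound 4 (0.69 log units; beyond the scatter). Compound 4 is therefore estimated at 20000 nM, with a range from 5000 nM to 100000 nM.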

Compound 4, concentration for total growth inhibition: 514 nM
Estimate against measurement, compound 4: 39-fold (1.59 log units) above, and the stated range ends above it.
By their numbers in this assay, from the lowest: compound 4; then compounds 3 and 2 (each within the scatter of the next). At a limit, above all of these: compound 1.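

The change from 4-acetylphenyl to 4-(dimethylamino)phenyl, on an aromatic carbon para to a large group, gives an at least 190-fold lower number from compound 1 to compound 4 (2.28 log units; beyond the scatter) in this assay. Compounds 2 and 3 each differ from compound 1 in more than one place, so they could not tie any difference to this group alone, whereas here the rest of the molecule stays the same and the swap at this one position separates a compound with no measurable value from one with a clear value. The value of compound 1 is a limit of the assay and not a number, so this step has only a lower bound: the limit of > 100000 nM in this assay, at which 1 of the 4 values shown sits.

The compounds shown place only acetyl and dimethylamino at this position in this pair, so they cannot tell whether the nitrogen, its two methyl groups or the loss of the carbonyl matters most. From the compounds shown here alone, a simple unsubstituted amine, a carboxylic acid or a longer chain on the nitrogen at the same place would help to answer that, and the size of the step on other cell lines also remains open.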